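The source may hold more compounds than are shown below. What is called first, only, known or untested is meant among the compounds shown, and "the series" means these compounds.

In a functional assay on MKN-45 cells (Homo sapiens) for inhibition, with a stated time of 72 h (a higher number here means a weaker inhibitor, a lower number a stronger inhibitor), three compounds have been measured so far. Compound 1 (`COc1ccc(S(=O)(=O)N2CCc3cccc(-c4ccc(F)nc4)c32)cc1`) gives 145 nM and compound 2 (`COc1ccc(S(=O)(=O)N2CCc3cccc(-c4ccc(F)cc4)c32)cc1`) gives 79 nM in that read-out, and these two values lie within the scatter of each other. Compound 3 (`COc1ccc(S(=O)(=O)n2ccc3cccc(-c4ccc(F)cc4)c32)cc1`) gives 170 nM as its number, and this stands higher than the number of compound 2 by a gap beyond the scatter. Compound 3 differs from compound 2 in the core and not in the aromatic group, so it offers no guide to a change of that group.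

Compound 4 (`COc1ccc(S(=O)(=O)N2CCc3cccc(-c4cccs4)c32)cc1`) has not yet been measured. It keeps the core of compound 2 and carries thiophen-2-yl in place of 4-fluorophenyl on an aromatic carbon. For the measured compounds named here, one measured step bears on this exchange of one aromatic ring for another, a 1.8-fold lower number from compound 1 to compound 2 (0.26 log units; within the scatter) and with that small step as the only guide, no shift beyond the scatter is expected in this assay and no firm direction can be given. The expected step is a 1.3-fold higher number from compound 2 to compound 4 (0.10 log units; within the scatter) as a working estimate. For compound 4 the expected value is 100 nM with an estimated range from 45 nM to 230 nM for repeated measurements.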

Compound 4, half-maximal inhibitory concentration: 165 nM
The estimate for compound 4 lay 1.7-fold (0.22 log units) below the measured number, and the stated range covers the measured number.
By their numbers in this assay, from the lowest: compounds 2, 1, 4 and 3 (each within the scatter of the next, the first and the last beyond it).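

In this assay, for the compounds shown here, putting thiophen-2-yl in place of 4-fluorophenyl on this aromatic carbon gives the first change of aromatic group on the shared core that goes beyond the scatter, though only modestly, with a 2.1-fold higher number from compound 2 to compound 4 (0.32 log units; beyond the scatter). The exchange of 6-fluoropyridin-3-yl for thiophen-2-yl stays within the scatter, with a 1.1-fold higher number from compound 1 to compound 4 (0.06 log units; within the scatter), so the only gap beyond the scatter among these three groups lies between 4-fluorophenyl and thiophen-2-yl, while 6-fluoropyridin-3-yl stays within the scatter of both. No measurement is available that bears on why this exchange produces a step of this size.

The compounds shown leave open whether an aromatic ring is needed at this carbon at all, since each compound on this core carries one there, and an amine, a carboxylic acid or a longer alkyl chain in its place would put that to the test. They also leave open whether the step from 4-fluorophenyl to thiophen-2-yl would keep its size on the core of compound 3, which is shown only with 4-fluorophenyl.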